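The source may report more compounds than this note shows. Statements on the series, on what has been measured and on what is new or still open speak of the compounds shown alone.

Compound 1 `CCc1ccc(NS(=O)(=O)c2ccc(N3CCNC3=O)cc2)cc1` gives 660 nM in a functional assay on HT-29 cells (Homo sapiens) for antiproliferative activity, read by sulforhodamine B assay, with a stated time of 48 h (on this read-out higher numbers stand for weaker inhibition and lower numbers for stronger inhibition), and stands highest of the two numbers recorded, with compound 2 `O=C1NCCN1c1ccc(S(=O)(=O)Nc2ccc(OC(F)F)cc2)cc1` nearest at 650 nM; the step of a 1.0-fold lower number from compound 1 to compound 2 (0.01 log units; within the scatter) is flat. Compound 3 `CCCCCCOc1ccc(NS(=O)(=O)c2ccc(N3CCNC3=O)cc2)cc1` reaches only a limit in this assay, > 1000 nM, and the limit of > 1000 nM in this assay, at which 1 of the 3 values shown sits, marks that value. Within the data shown here, the steps of an at least 1.5-fold higher number from compound 1 to compound 3 (0.18 log units; that floor lies within the scatter) and an at least 1.5-fold higher number from compound 2 to compound 3 (0.18 log units; that floor lies within the scatter) have floors that sit inside the scatter, so no measured step in this assay moves beyond it.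

Compound 4 `COc1ccccc1NS(=O)(=O)c1ccc(N2CCNC2=O)cc1` is still to be measured. The change from compound 1 is 2-methoxyphenyl in place of 4-ethylphenyl on a sulfonamide nitrogen. Among the measured compounds shown here, no measured step swaps the whole ring on the sulfonamide nitrogen, and the steps that do exist stay within the scatter, so a step of a 1.1-fold higher number from compound 1 to compound 4 (0.06 log units; within the scatter) is expected for compound 4, with an estimate of 750 nM lying between 300 nM and 1800 nM in this assay.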

Compound 4, half-maximal inhibitory concentration: 550 nM
The estimate for compound 4 lay 1.4-fold (0.13 log units) above the measured number; the range from low to high includes it.
By their numbers in this assay, from the lowest: compounds 4, 2 and 1 (each within the scatter of the next). At a limit, above all of these: compound 3.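

Exchanging the whole group on the sulfonamide nitrogen gives a 1.2-fold lower number from compound 1 to compound 4 (0.08 log units; within the scatter) in this assay and so leaves the number flat. This position therefore accepts 2-methoxyphenyl as well as 4-ethylphenyl, even though 2-methoxyphenyl brings a hydrogen-bond acceptor that 4-ethylphenyl lacks. Nothing available accounts for this flat step.

Still open, from the compounds shown here alone, is whether an amine or a carboxylic acid on this ring would shift the number beyond the scatter. A butoxy chain, intermediate between the ethyl of compound 1 and the hexyloxy of compound 3, also remains to be placed.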